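The source may hold more compounds than are shown below. What is called first, only, known or untested is meant among the compounds shown, and "the series" means these compounds.

In a functional assay on MDA-MB-231 cells (Homo sapiens) for cytotoxicity, read by MTT assay, with a stated time of 72 h (on this read-out lower numbers stand for stronger inhibition and higher numbers for weaker inhibition), compound 1 `CCN(CC)CCCNc1nc(-c2ccc(NC(=O)Nc3ccccc3F)cc2)nc2ccsc12` gives 860 nM. Compound 2 `CCN(CC)CCCNc1nc(-c2ccc(NC(=O)Nc3ccc(Cl)cc3)cc2)nc2ccsc12` gives 230 nM. Compound 3 `CCN(CC)CCNc1nc(-c2ccc(NC(=O)Nc3ccccc3F)cc2)nc2ccsc12` gives 580 nM.

Compound 2 differs from compound 1 by 4-chlorophenyl in place of 2-fluorophenyl on an amide-type nitrogen, and this change brought a 3.7-fold lower number from compound 1 to compound 2 (0.57 log units; beyond the scatter). Compound 3 differs from compound 1 by diethylamino in place of (diethylamino)methyl on a saturated chain carbon, two bonds along the chain from a nitrogen on an aromatic ring, which gave only a 1.5-fold lower number from compound 1 to compound 3 (0.17 log units; within the scatter). Compound 4 `CCN(CC)CCNc1nc(-c2ccc(NC(=O)Nc3ccc(Cl)cc3)cc2)nc2ccsc12` is not yet measured; it differs from compound 3 by 4-chlorophenyl in place of 2-fluorophenyl on an amide-type nitrogen, the same change at the same place as from compound 1 to compound 2, now made on the shorter-chain core of compound 3. The step is expected to be of similar size, a 3.4-fold lower number from compound 3 to compound 4 (0.53 log units; beyond the scatter), because the same change gave a 3.7-fold lower number from compound 1 to compound 2 (0.57 log units; beyond the scatter) once already, with the usual scatter allowing some deviation. The estimate for compound 4 is 170 nM, roughly between 80 nM and 360 nM.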

Compound 4, half-maximal inhibitory concentration: 550 nM
Beside the measured number, compound 4's estimate is 3.2-fold (0.51 log units) below it; measured number outside the range, above it.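

In this assay, the change from 2-fluorophenyl to 4-chlorophenyl did not carry over to the shorter-chain core, where it gave a 1.1-fold lower number from compound 3 to compound 4 (0.02 log units; within the scatter); the two cores responded differently: the same change on two cores in this assay, a 3.7-fold lower number (0.57 log units; beyond the scatter) from compound 1 to compound 2 and a 1.1-fold lower number (0.02 log units; within the scatter) from compound 3 to compound 4, 3.5-fold (0.55 log units) apart, beyond the scatter of two such steps. The shorter chain also behaved differently with 4-chlorophenyl in place, giving a 2.4-fold higher number from compound 2 to compound 4 (0.38 log units; beyond the scatter); its effect was not the same with the two aryl groups: the same change on two cores in this assay, a 1.5-fold lower number (0.17 log units; within the scatter) from compound 1 to compound 3 and a 2.4-fold higher number (0.38 log units; beyond the scatter) from compound 2 to compound 4, 3.5-fold (0.55 log units) apart, beyond the scatter of two such steps. The two changes are therefore not additive across these four compounds, but this set does not show why, or whether the same holds for other groups.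

Going by these compounds, what a 4-methoxyphenyl on the amide-type nitrogen would do on either chain remains open. So does the outcome with a morpholine in place of diethylamino, or with a longer chain.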